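The source may hold more compounds than are shown below. What is called first, only, known or untested is meant among the compounds shown, and "the series" means these compounds.

Measured in a functional assay on PC-3 cells (Homo sapiens) for cytotoxicity; a higher number here means a weaker inhibitor, a lower number a stronger inhibitor:

- compound 1 `COc1ccc2c(c1)c(/C=N\NC(=O)c1cn(C)c3ccccc13)cn2Cc1ccc(Cl)cc1`: 21200 nM
- compound 2 `COc1ccc2c(c1)c(/C=N\NC(=O)c1c[nH]c3ccccc13)cn2Cc1ccc(Cl)cc1`: 30300 nM
- compound 3 `O=C(N/N=C\c1cn(Cc2ccc(Cl)cc2)c2cc(F)ccc12)c1c[nH]c2ccccc12`: 19500 nM

Compound 2 and compound 1 differ by methyl in place of hydrogen on an aromatic nitrogen; that change produced a 1.4-fold lower number from compound 2 to compound 1 (0.16 log units; within the scatter). The difference between the cores of compound 2 and compound 3 is not broken down here. Compound 3 stands near compound 1, and the values of compound 3 and compound 2 are within the scatter of each other, so no ordering among the three is claimed.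

Compound 4 `Cn1cc(C(=O)N/N=C\c2cn(Cc3ccc(Cl)cc3)c3cc(F)ccc23)c2ccccc21` is still to be measured in this assay. It is related to compound 3 by methyl in place of hydrogen on an aromatic nitrogen, a change of the same kind as that between compound 2 and compound 1, at a place described in the same words.

For the measured compounds named here, the only precedent, a 1.4-fold lower number from compound 2 to compound 1 (0.16 log units; within the scatter), lies within the scatter, and the step from compound 3 to compound 4 is expected to be of similar size, a 1.3-fold lower number from compound 3 to compound 4 (0.11 log units; within the scatter). On that basis compound 4 is estimated at 15000 nM, with an expected range from 7000 nM to 35000 nM.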

Compound 4, half-maximal inhibitory concentration: 22100 nM
Compound 4: the middle estimate sits 1.5-fold (0.17 log units) below what was measured; the range from low to high includes it.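

Notes on the methyl change: in this assay, methyl in place of hydrogen on the aromatic nitrogen, which turns 1H-indol-3-yl into 1-methyl-1H-indol-3-yl, gives a 1.1-fold higher number from compound 3 to compound 4 (0.05 log units; within the scatter) and so leaves the read-out unresolved on this core. Set beside the earlier pair, the change reads alike on the core of compound 2 and the core of compound 3: the same change on two cores in this assay, a 1.4-fold lower number (0.16 log units; within the scatter) from compound 2 to compound 1 and a 1.1-fold higher number (0.05 log units; within the scatter) from compound 3 to compound 4, 1.6-fold (0.21 log units) apart, within the scatter of two such steps. This shows only that neither of these two cores yields a step beyond the scatter; it gives no direction for the change and no evidence of a real effect, and two pairs do not make a rule for other cores.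

Open, going by these compounds, is whether any other group on that aromatic nitrogen, such as a longer chain or a chain ending in an amine or a carboxylic acid, would move the number beyond the scatter. Also open, on these data alone, is whether the same flat reading would hold on a core carrying neither the methoxy nor the fluoro group.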